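A few compounds are considered here, and "the series" means these few. Any claim that something is new, unique, unknown or untested is made for them only; others in the source may bear on it.

Measured compounds:
- compound 1 `CC1(C)O[C@@H](CO)[C@H](Cn2cc(Cn3c4c(c5ccccc53)C(=O)c3c[n+]([O-])c5ccccc5c3C4=O)nn2)O1`: 190 nM
- compound 2 `O=C1c2c[n+]([O-])c3ccccc3c2C(=O)c2c1c1ccccc1n2Cc1cn(CC(O)CO)nn1`: 440 nM
- compound 3 `CC1(C)OC[C@@H](Cn2cc(Cn3c4c(c5ccccc53)C(=O)c3c[n+]([O-])c5ccccc5c3C4=O)nn2)O1`: 450 nM

All three were tested in a functional assay on A-375 cells (Homo sapiens) for cytotoxicity, read by MTT assay, with a stated time of 72 h; a lower number here means a stronger inhibitor, a higher number a weaker inhibitor. Compound 2 stands second highest of the three numbers: compound 3 is nearest, with a 1.0-fold higher number from compound 2 to compound 3 (0.01 log units; within the scatter), while compound 1 is furthest, with a 2.3-fold higher number from compound 1 to compound 2 (0.36 log units; beyond the scatter). Compound 4 `O=C1c2c[n+]([O-])c3ccccc3c2C(=O)c2c1c1ccccc1n2CCN1CCCCC1` differs from compound 2 in one place: (piperidin-1-yl)methyl in place of 1-(2,3-dihydroxypropyl)-1H-1,2,3-triazol-4-yl on a saturated chain carbon bound to an aromatic nitrogen. The measured steps only exchange the group hanging on the triazole, and both such exchanges were modest, a 2.3-fold higher number from compound 1 to compound 2 (0.36 log units; beyond the scatter) and a 2.4-fold higher number from compound 1 to compound 3 (0.37 log units; beyond the scatter). Among the measured compounds shown here, no measured step removes the triazole itself or brings in a piperidine ring, so the change to compound 4 lies outside what the measured steps cover. Compound 4 is therefore expected near compound 2, with a 1.1-fold lower number from compound 2 to compound 4 (0.04 log units; within the scatter), and a wide range: estimated 400 nM, from 120 nM to 1500 nM.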

Compound 4, half-maximal inhibitory concentration: 180 nM
The estimate for compound 4 lay 2.2-fold (0.35 log units) above the measured number; the measured number falls inside the stated range.
By their numbers in this assay, from the lowest: compounds 4 and 1 (each within the scatter of the next); then compounds 2 and 3 (each within the scatter of the next).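

In this assay, replacing the 1-(2,3-dihydroxypropyl)-1H-1,2,3-triazol-4-yl group with (piperidin-1-yl)methyl gives a 2.4-fold lower number from compound 2 to compound 4 (0.39 log units; beyond the scatter) and so a stronger inhibitor. The earlier steps shown here only exchanged the group on the triazole, whereas this one shows that, on this saturated chain carbon, the triazole and its two hydroxyl groups can both go without any loss of strength. No measurement at hand explains this gain.

Since everything changes at once, the compounds shown cannot separate the loss of the triazole from the gain of the piperidine ring. On these data alone, how a morpholine ring or an open-chain dimethylamino group would behave in the same place also remains open.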